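A few compounds are considered here, and "the series" means these few. Any claim that something is new, unique, unknown or untested is made for them only; others in the source may bear on it.

In a functional assay on A549 cells (Homo sapiens) for cytotoxicity, with a stated time of 48 h (on this read-out lower numbers stand for stronger inhibition and higher numbers for weaker inhibition), compound 1 (`CCCCOc1ccc2oc(/C=C/[S+](C)[O-])cc(=O)c2c1`) gives 1400 nM and compound 2 (`C[S+]([O-])/C=C/c1cc(=O)c2cc(F)ccc2o1`) gives 2100 nM, which places compound 2 level with compound 1: the measured change is a 1.5-fold higher number from compound 1 to compound 2 (0.18 log units; within the scatter). Compound 3 (`COc1ccc2oc(/C=C/[S+](C)[O-])cc(=O)c2c1`) has methoxy in place of fluoro on an aromatic carbon, (methoxy in place of fluoro on an aromatic carbon). Within the data shown here, only one measured step bears on this exchange, the swap of butoxy for fluoro in a 1.5-fold higher number from compound 1 to compound 2 (0.18 log units; within the scatter), and it stays within the scatter. No change beyond the scatter is therefore expected in this assay, and the expected change is a 1.2-fold lower number from compound 2 to compound 3 (0.09 log units; within the scatter). Compound 3 is estimated at 1700 nM, with an expected range of 800 nM to 3600 nM.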

Compound 3, half-maximal inhibitory concentration: 1600 nM
Compound 3: the middle estimate sits 1.1-fold (0.03 log units) above what was measured; the range from low to high includes it.
By their numbers in this assay, from the lowest: compounds 1, 3 and 2 (each within the scatter of the next).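

In this assay, this aromatic carbon now carries fluoro, methoxy or butoxy, and no exchange among them moves the number beyond the scatter: methoxy in place of fluoro gives a 1.3-fold lower number from compound 2 to compound 3 (0.12 log units; within the scatter), and hydrogen in place of propyl on the chain gives a 1.1-fold higher number from compound 1 to compound 3 (0.06 log units; within the scatter). The chain on the oxygen can therefore be shortened from butoxy to methoxy with the read-out staying level, which the earlier pair alone could not show. Nothing available speaks to a cause of this. On these data alone, whether an amine or a carboxylic acid at this place would move the number beyond the scatter stays open. So does whether any change elsewhere on the shared core would do so.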